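Swapping a Chlorinated Ring for a Difluorinated One

The compounds below may be only part of what the source reports. "The series", "measured", "known", "first", "only" and "open" are said of these compounds alone.

Compound 2, `CCN1CCN(c2cc(C)c3cc(NC(=O)c4ccc(Cl)cc4)ccc3n2)CC1`: 1530 nM
Compound 1, `Cc1cc(NCCN2CCN(C)CC2)nc2ccc(NC(=O)c3ccc(Cl)c(Cl)c3)cc12`: 1700 nM

Of the compounds shown here, two have been measured in a functional assay on MCF7 cells (Homo sapiens) for antiproliferative activity, read by MTT assay, with a stated time of 72 h; a higher number here means a weaker inhibitor, a lower number a stronger inhibitor. Compound 2 gives 1530 nM, the lowest of the two numbers, while compound 1 gives 1700 nM; the gap between them lies within the usual scatter, so the two cannot be told apart. Compound 1 and compound 2 differ from each other in several places at once, so no single step can be read from that pair.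

The next compound, compound 3 `CCN1CCN(c2cc(C)c3cc(NC(=O)c4ccc(F)c(F)c4)ccc3n2)CC1`, is built from compound 2 by one change: 3,4-difluorophenyl in place of 4-chlorophenyl on a carbonyl carbon. Both groups are six-membered aromatic rings of carbon only, without hydrogen-bond donors or acceptors and without net charge; what changes is the halogen pattern on that ring. Going by the values given here, no measured pair shows this change, so there is no measured step to lean on. The step expected in this assay, a 1.2-fold higher number from compound 2 to compound 3 (0.07 log units; within the scatter), is small, within the scatter, with a slight lean toward a weaker inhibitor. Compound 3 is therefore expected to give about 1800 nM, between 900 nM and 3600 nM.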

Compound 3, half-maximal inhibitory concentration: 5230 nM
For compound 3 the middle estimate is 2.9-fold (0.46 log units) below the measured one; measured number outside the range, above it.
By their numbers in this assay, from the lowest: compounds 2 and 1 (each within the scatter of the next); then compound 3.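

Going by these compounds alone, this is the first measured step for the group on this carbonyl carbon: in this assay, 3,4-difluorophenyl in place of 4-chlorophenyl gives a 3.4-fold higher number from compound 2 to compound 3 (0.53 log units; beyond the scatter) and so a modestly weaker inhibitor, by a margin beyond the usual scatter. The halogen pattern on this ring therefore counts in this read-out, even though both groups are six-membered aromatic rings of carbon only, with no hydrogen-bond donors or acceptors and no net charge. No measurement at hand bears on why the number rises.

This one step changes both the kind of halogen and how many the ring carries, and compound 1 differs from the other two in several places, so the steps to compound 1 cannot be read and the two parts of the change stay unseparated. A 4-fluorophenyl group on the same carbonyl carbon would isolate the swap of chlorine for fluorine, while a 4-methoxyphenyl group would test whether a halogen is needed on this ring at all.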